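Changing One End of Compound 1

The source may report more compounds than this note shows. Statements on the series, on what has been measured and on what is new or still open speak of the compounds shown alone.

In a functional assay on MDA-MB-435 cells (Homo sapiens) for inhibition, read by sulforhodamine B assay, with a stated time of 48 h (on this read-out lower numbers stand for higher toxicity in this test and higher numbers for lower toxicity in this test), compound 1 `COc1cc(-c2nn(-c3cccc(NC(=O)Nc4ccc(Cl)c(Cl)c4)c3)cc2-c2ccncc2)ccc1Cl` gives > 50000 nM, which is a limit and not a number. Compound 2 `O=C(Nc1cccc(-n2cc(-c3ccncc3)c(-c3ccc(Cl)c(O)c3)n2)c1)Nc1ccc(Cl)c(Cl)c1` gives > 32500 nM, which is also a limit.

Compound 3 `COc1cc(-c2nn(-c3cccc(NC(=O)c4ccccc4)c3)cc2-c2ccncc2)ccc1Cl` keeps the core of compound 1 but differs at one end: phenyl in place of (3,4-dichlorophenyl)amino on a carbonyl carbon.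

Among the measured compounds shown here, the only measured change is a step that the two limits leave unreadable from compound 1 to compound 2. It is a different change from this one, and it offers no size to carry over. The expected step, a number no higher from compound 1 to compound 3 (the limit leaves the size open), is therefore none beyond the scatter, with no direction favoured. In this assay the estimate for compound 3 is 50000 nM, with an expected range of 20000 nM to 100000 nM.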

Compound 3, concentration lethal to 50% of the cells: 12300 nM
Beside the measured number, compound 3's estimate is 4.1-fold (0.61 log units) above it; measured number below the stated range.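

In this assay, phenyl in place of (3,4-dichlorophenyl)amino on a carbonyl carbon gives an at least 4.0-fold lower number from compound 1 to compound 3 (0.60 log units; beyond the scatter), and here a lower number stands for higher toxicity in this test. Among the compounds shown here, this is the first step with a readable direction, and it shows that the group on this carbonyl carbon is a place where the read-out can move. The true step may be larger than the printed size, since the value of compound 1 is only a limit: the limit of > 50000 nM in this assay, at which 1 of the 3 values shown sits.

The change takes away the amino nitrogen, with its hydrogen-bond donor, and both chlorines at once, and the compounds shown cannot tell which of these accounts for the step. On these data alone, how a cyclohexyl group or a dimethylamino group on the same carbonyl carbon would read also remains open.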